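This account rests on a few compounds, and the source may have more. Where it says the series, first, only, none or still open, it means among the compounds named here.

Measured in a functional assay on HepG2 cells (Homo sapiens) for antiproliferative activity, read by MTT assay, with a stated time of 72 h; a lower number here means a stronger inhibitor, a higher number a weaker inhibitor:
- compound 1 `CN(C)CCn1cccc1/C=N/NC(=O)Nc1ccc(Oc2ccnc3[nH]ccc23)c(F)c1`: 8980 nM
- compound 2 `O=C(N/N=C/c1cccn1CCCN1CCCCC1)Nc1ccc(Oc2ccnc3[nH]ccc23)c(F)c1`: 2840 nM

Of these two, compound 2 has the lower number, at 2840 nM. Compound 3 `CN1CCN(CCCn2cccc2/C=N/NC(=O)Nc2ccc(Oc3ccnc4[nH]ccc34)c(F)c2)CC1` differs from compound 2 in one place: 4-methylpiperazin-1-yl in place of piperidin-1-yl on a saturated chain carbon, three bonds along the chain from an aromatic nitrogen. Within the data shown here, the only measured step that bears on this change is a 3.2-fold lower number from compound 1 to compound 2 (0.50 log units; beyond the scatter). Among the measured compounds shown here, that step is modest and exchanges different groups, and no measured pair makes this exact exchange, so no step beyond the scatter is expected. The expected change is a 1.1-fold higher number from compound 2 to compound 3 (0.02 log units; within the scatter). The estimate for compound 3 is 3000 nM, with an expected range of 1000 nM to 9000 nM.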

Compound 3, half-maximal inhibitory concentration: 2740 nM
For compound 3 the middle estimate is 1.1-fold (0.04 log units) above the measured one, and the stated range covers the measured number.
By their numbers in this assay, from the lowest: compounds 3 and 2 (each within the scatter of the next); then compound 1.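

In this assay, 4-methylpiperazin-1-yl in place of piperidin-1-yl, on a saturated chain carbon three bonds along the chain from an aromatic nitrogen, gives no step beyond the scatter (a 1.0-fold lower number from compound 2 to compound 3 (0.02 log units; within the scatter)). The step from the dimethylamino end group also holds for this second ring (a 3.3-fold lower number from compound 1 to compound 3 (0.52 log units; beyond the scatter)), so compound 2 and compound 3 both stand apart from compound 1. No measurement shown here explains these numbers.

Going by these compounds, whether morpholin-4-yl or a free primary amine at this place would give a different number remains open. So does the effect of a longer chain carrying 4-methylpiperazin-1-yl.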